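Thiadiazoline amides: cyclohexyl to phenyl on a chloro core

The source may report more compounds than this note shows. Statements on the series, on what has been measured and on what is new or still open speak of the compounds shown alone.

Compound 1 `COc1ccc(N)c(C2=NN(C(=O)C3CCCCC3)C(C)(C)S2)c1` gives 100% in an assay on isolated protein for inhibition of Nitric oxide synthase, inducible (Homo sapiens), read by scintillation counting, with a stated time of 30 min, tested at 50 uM; a lower number here means less inhibition, a higher number more inhibition at the concentration tested (going by the name of the read-out). Compound 2 `COc1ccc(N)c(C2=NN(C(=O)c3ccccc3)C(C)(C)S2)c1`, which differs by phenyl in place of cyclohexyl on a carbonyl carbon, gives 0% in this assay, so the step of a number 100 percentage points lower from compound 1 to compound 2 (beyond the scatter) is the largest change seen. Compound 3 `CC1(C)SC(c2cc(Cl)ccc2N)=NN1C(=O)C1CCCCC1` carries a different core, described by chloro in place of methoxy on an aromatic carbon, and gives 7.61% in this assay; the step of a number 92.4 percentage points lower from compound 1 to compound 3 (beyond the scatter) is also large. Compound 3 and compound 2 lie within the usual scatter of each other, so no order between them is claimed.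

Compound 4 `CC1(C)SC(c2cc(Cl)ccc2N)=NN1C(=O)c1ccccc1` is not yet measured. It differs from compound 3 by phenyl in place of cyclohexyl on a carbonyl carbon, and the place of the change is the same as in the earlier pair, so this is the same change that gave a number 100 percentage points lower from compound 1 to compound 2 (beyond the scatter). The step is expected to be much smaller this time because compound 3 at 7.61% leaves little room for a further drop, and the expected step from compound 3 is a number 4.6 percentage points lower from compound 3 to compound 4 (within the scatter). Compound 4 is expected at about 3%, in an estimated range from -8% to 15%.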

Compound 4, a percentage reported as inhibition, at one concentration (the size of the read-out at that concentration, not a potency): 20.8%
Compound 4: middle estimate off by 17.8 percentage points, on the low side; the whole stated range lies below it.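

In this assay, phenyl in place of cyclohexyl on a carbonyl carbon gives a number 13.2 percentage points higher from compound 3 to compound 4 (beyond the scatter), so the change does not carry over from the core of compound 1 to the chloro core, in size or in direction: the same change on two cores in this assay, a number 100 percentage points lower (beyond the scatter) from compound 1 to compound 2 and a number 13.2 percentage points higher (beyond the scatter) from compound 3 to compound 4, 113.2 percentage points apart, beyond the scatter of two such steps Read the other way round the same square, chloro in place of methoxy on an aromatic carbon gives a number 20.8 percentage points higher from compound 2 to compound 4 (beyond the scatter) with the phenyl amide, so that change also depends on its partner group: the same change on two cores in this assay, a number 92.4 percentage points lower (beyond the scatter) from compound 1 to compound 3 and a number 20.8 percentage points higher (beyond the scatter) from compound 2 to compound 4, 113.2 percentage points apart, beyond the scatter of two such steps These four readings at one concentration show that the two changes do not act independently here, but they give no potencies, do not show why the changes interact, and do not extend to other groups.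

On these data alone, it remains open whether the high reading of compound 1 needs cyclohexyl and methoxy together, or whether a cyclopentyl group or a longer alkyl chain on the carbonyl carbon would keep it on the methoxy core. Also open, as far as these compounds go, is how a fluoro or ethoxy group in place of methoxy on the aromatic carbon would read with the cyclohexyl amide.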